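This account rests on a few compounds, and the source may have more. Where it says the series, first, only, none or still open, it means among the compounds named here.

Compounds 2 and 3 share one core and are both measured in an assay for inhibition of solute carrier family 22 member 12 (Homo sapiens), read by scintillation counting, with a stated time of 60 min; a higher number here means a weaker inhibitor, a lower number a stronger inhibitor. Compound 2 is `CCc1oc2ccc(OC)cc2c1C(=O)c1ccc(O)cc1`; in this assay compound 2 gives 2460 nM. Compound 3 is `CCc1oc2ccc(O)cc2c1C(=O)c1ccc(O)cc1`; in this assay compound 3 gives 2490 nM. The change between the two is hydrogen in place of methyl on an oxygen on an aromatic ring and the step it made is a 1.0-fold higher number from compound 2 to compound 3 (0.01 log units; within the scatter), so the two values cannot be told apart.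

Compound 1 is `CCc1cc2cc(OC)cc(C(=O)c3ccc(OC)cc3)c2o1` and sits on a different core; in this assay compound 1 is recorded as "not determined" (no result reported), so there is no number for it. The difference between the two cores is not broken down here. Compound 4 is `CCc1cc2cc(OC)cc(C(=O)c3ccc(O)cc3)c2o1` and has not yet been measured in this assay. Compound 4 differs from compound 1 by hydrogen in place of methyl on an oxygen on an aromatic ring; the place is the same word for word as in the pair of compound 2 and compound 3, so this is the same change.

For the measured compounds named here, for the step from compound 1 to compound 4 in this assay a size like the one from compound 2 to compound 3 is expected, that is a step within the scatter, resting on a 1.0-fold higher number from compound 2 to compound 3 (0.01 log units; within the scatter). With no number for compound 1, the level of compound 4 can only be anchored to compound 2 at 2460 nM and compound 3 at 2490 nM, on a core that differs in a way not broken down here, so the range is set wide. Compound 4 is expected to give about 2500 nM in this assay, most likely between 500 nM and 12000 nM.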

Compound 4, half-maximal inhibitory concentration: 33700 nM
Compound 4: middle estimate off by 13-fold (1.13 log units), on the low side, outside the stated range (above it).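

In this assay, for the compounds shown here, compound 1 stands at "not determined" (no result reported) and compound 4 at 33700 nM, so no step between compound 1 and compound 4 can be read. The compounds shown leave open whether methoxy to hydroxy on the core of compound 1 gives a step like a 1.0-fold higher number from compound 2 to compound 3 (0.01 log units; within the scatter). No evidence at hand bears on the result for compound 4.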